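Changing the Ring Attached to the Urea Nitrogen

The source may hold more compounds than are shown below. What is called first, only, known or untested is meant among the compounds shown, and "the series" means these compounds.

Compound 1 `Cc1nc2cc(NC(=O)N3CCN(Cc4cccc(Oc5ccc(Cl)cc5)c4)CC3)ccc2o1` is a urea carrying a fused ring group on an amide-type nitrogen. In an assay on isolated protein for inhibition of Fatty-acid amide hydrolase 1 (Rattus norvegicus), with a stated time of 60 min (on this read-out lower numbers stand for stronger inhibition and higher numbers for weaker inhibition), compound 1 gives 200 nM, the higher of the two numbers measured here. Compound 2 `O=C(Nc1noc2cccnc12)N1CCN(Cc2cccc(Oc3ccc(Cl)cc3)c2)CC1` gives 22 nM, and a 9.1-fold lower number from compound 1 to compound 2 (0.96 log units; beyond the scatter). Compound 3 `O=C(Nc1cn2ccccc2n1)N1CCN(Cc2cccc(Oc3ccc(Cl)cc3)c2)CC1` gives > 10000 nM, which is a limit of the assay rather than a number. Compound 4 `O=C(Nc1cccc2nccn12)N1CCN(Cc2cccc(Oc3ccc(Cl)cc3)c2)CC1` is unmeasured and carries a group of 9 heavy atoms (7 carbon, 2 nitrogen; one five-membered aromatic ring with 2 hetero atoms, one six-membered aromatic ring with 1 hetero atom) in place of a group of 10 heavy atoms (8 carbon, 1 nitrogen, 1 oxygen; one five-membered aromatic ring with 2 hetero atoms, one six-membered aromatic ring of carbon only), on an amide-type nitrogen. Its entering group matches that of compound 3 in atom counts, so the step of an at least 50-fold higher number from compound 1 to compound 3 (1.69 log units; beyond the scatter) bears most directly on it, whereas the step to compound 2 involved a ring of different composition. A weaker result is therefore expected for compound 4, with a 15-fold higher number from compound 1 to compound 4 (1.18 log units; beyond the scatter). Compound 4 is estimated at 3000 nM, spanning 300 nM to 30000 nM.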

Compound 4, half-maximal inhibitory concentration: 5.7 nM
Beside the measured number, compound 4's estimate is 530-fold (2.72 log units) above it; the whole stated range lies above it.
By their numbers in this assay, from the lowest: compound 4; then compound 2; then compound 1. At a limit, above all of these: compound 3.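

Two groups with matching atom counts and ring types can give very different results here, with an at least 1700-fold lower number from compound 3 to compound 4 (3.24 log units; beyond the scatter) despite that match, although compound 3 stands at a limit of the assay and not at a number. At this amide-type nitrogen, then, the arrangement of the ring atoms matters, not their count alone. The entering group also outdoes the other measured groups, with a 35-fold lower number from compound 1 to compound 4 (1.55 log units; beyond the scatter) and with a 3.9-fold lower number from compound 2 to compound 4 (0.59 log units; beyond the scatter) as well. Still open, on these data alone, is whether a single ring such as phenyl or pyridine on this nitrogen would do as well, and whether a methyl group on the new ring would change the number.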